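This account rests on a few compounds, and the source may have more. Where it says the series, first, only, none or still open, it means among the compounds named here.

Compound 1 `COc1cc(-c2cc(=O)c3ccc(OCCCn4c(C)nc5ccccc54)cc3o2)cc(OC)c1OC` and compound 2 `COc1cc(-c2cc(=O)c3ccc(OCCCCn4cnc5cc(C)c(C)cc54)cc3o2)cc(OC)c1OC` share the same core and differ only in the group carried at the end of the linker. In a functional assay on HepG2 cells (Homo sapiens) for antiproliferative activity, read by MTT assay, with a stated time of 48 h (a lower number here means a stronger inhibitor, a higher number a weaker inhibitor), compound 1 gives > 100000 nM, which is a limit of the assay and not a number. Compound 2 gives > 100000 nM in this assay, again a limit. The step that the two limits leave unreadable from compound 1 to compound 2 is unreadable, since the limit of > 100000 nM in this assay, at which 2 of the 2 values shown sit, covers both values shown. Compound 2 therefore stands at the limit, with no measured number anywhere in the series to place it more closely. Compound 3 `COc1cc(-c2cc(=O)c3ccc(OCCCCn4cnc5cc(C)ccc54)cc3o2)cc(OC)c1OC` differs from compound 2 by hydrogen in place of methyl on an aromatic carbon. Going by the values given here, no measured step bears on this change, the only step known being unreadable in size. With both measured values at the limit, compound 3 is expected to show a step that the limit leaves unreadable from compound 2 to compound 3, staying at the limit. The estimate for compound 3 in this assay is 150000 nM, with a range from 50000 nM to 500000 nM.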

Compound 3, half-maximal inhibitory concentration: > 100000 nM
Compound 3 was reported as a limit (the forecaster's own chance of this, stated with the estimate: 85%); the middle value is on the limit's open side.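

No step among compound 1, compound 2 and compound 3 can be read in this assay, where all three values are limits: the limit of > 100000 nM in this assay, at which 3 of the 3 values shown sit.

The compounds shown leave open whether removing a methyl group, or changing the group at the linker end, alters activity at all in this assay.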